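Swapping benzyloxy for 2-cyclopentylethoxy on the shared core

This account rests on a few compounds, and the source may have more. Where it says the series, first, only, none or still open, it means among the compounds named here.

Compound 1 `CC(C)(C)CCOc1cccc(O)c1C(=O)/C=C/c1ccc(O)cc1`: 3130 nM
Compound 2 `O=C(/C=C/c1ccc(O)cc1)c1c(O)cccc1OCCC1CCCCC1`: > 30000 nM (a limit)
Compound 3 `O=C(/C=C/c1ccc(O)cc1)c1c(O)cccc1OCc1ccccc1`: > 30000 nM (a limit)

In a functional assay on NCI-H23 cells (Homo sapiens) for antiproliferative activity, read by sulforhodamine B assay (a lower number here means a stronger inhibitor of growth, a higher number a weaker inhibitor of growth), compound 3 stands only at a limit, > 30000 nM (no number). Compound 4 `O=C(/C=C/c1ccc(O)cc1)c1c(O)cccc1OCCC1CCCC1` carries cyclopentylmethyl in place of phenyl, (cyclopentylmethyl in place of phenyl on a saturated chain carbon bound to an oxygen on an aromatic ring), on a saturated chain carbon bound to an oxygen on an aromatic ring. Going by the values given here, two measured steps bear on this: an at least 9.5-fold higher number from compound 1 to compound 2 (0.98 log units; beyond the scatter) and an at least 9.5-fold higher number from compound 1 to compound 3 (0.98 log units; beyond the scatter), both beyond the scatter and both leading to limits. Only compound 1 gives a number, and a step that the two limits leave unreadable from compound 2 to compound 3 cannot be read. A modest move to a lower number is therefore expected, namely an at least 2.0-fold lower number from compound 3 to compound 4 (0.30 log units; that floor lies within the scatter) as the estimated step. Compound 4 is estimated at 15000 nM, with an expected range from 5000 nM to 30000 nM as its ends.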

Compound 4, concentration for 50% growth inhibition: 3370 nM
Compound 4: the middle estimate sits 4.5-fold (0.65 log units) above what was measured, and the stated range ends above it.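

In this assay, 2-cyclopentylethoxy gives a measurable value on the shared core where benzyloxy gives only a limit, with an at least 8.9-fold lower number from compound 3 to compound 4 (0.94 log units; beyond the scatter). The chain end also tolerates a cyclopentyl but not a cyclohexyl, with an at least 8.9-fold lower number from compound 2 to compound 4 (0.94 log units; beyond the scatter), while cyclopentyl and tert-butyl cannot be told apart, with a 1.1-fold higher number from compound 1 to compound 4 (0.03 log units; within the scatter). Both steps that start from a limit give only a floor for their size: the limit of > 30000 nM in this assay, at which 2 of the 4 values shown sit.

On these data alone, whether a cyclobutyl end or a longer chain would hold or lower this value remains open. So does the effect of an amine at the chain end.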